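The source may report more compounds than this note shows. Statements on the series, on what has been measured and on what is new or still open speak of the compounds shown alone.

Measured so far in a functional assay on cells for antagonist activity at prostaglandin E2 receptor EP1 subtype (Rattus norvegicus), read by fluorescence and calcium flux, with a stated time of 60 s; on this read-out higher numbers stand for weaker inhibition and lower numbers for stronger inhibition: compound 1 `O=C(O)c1cccc(Cc2c(-c3ccc(Cl)cc3)nn3cc(Cl)ccc23)n1` with 1100 nM and compound 2 `O=C(O)c1cccc(Cc2c(-c3ccsc3)nn3cc(Cl)ccc23)n1` with 110 nM.

Among these two numbers compound 1 stands highest, meaning it inhibits more weakly than compound 2. The unmeasured compound 3 `O=C(O)c1cccc(Cc2c(N3CCCCC3)nn3cc(Cl)ccc23)n1` differs from compound 1 in one place: piperidin-1-yl in place of 4-chlorophenyl on an aromatic carbon. Among the measured compounds shown here, the only measured step touches the same position, a 10-fold lower number from compound 1 to compound 2 (1.00 log units; beyond the scatter), but it swaps one aromatic ring for another, whereas here a non-aromatic ring with a nitrogen enters. That step gives no direct guide, so for compound 3 a modest change in either direction, or none beyond the scatter, is expected, a 1.8-fold higher number from compound 1 to compound 3 (0.26 log units; within the scatter). Compound 3 is estimated at 2000 nM, with a likely range from 500 nM to 8000 nM.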

Compound 3, half-maximal inhibitory concentration: 79 nM
Compound 3: middle estimate off by 25-fold (1.40 log units), on the high side, outside the stated range (below it).
By their numbers in this assay, from the lowest: compounds 3 and 2 (each within the scatter of the next); then compound 1.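

In this assay, the carbon that bears these groups does not need an aromatic ring: piperidin-1-yl in place of 4-chlorophenyl gives (a 14-fold lower number from compound 1 to compound 3 (1.14 log units; beyond the scatter)). The non-aromatic ring also matches the smaller aromatic thiophen-3-yl, with (a 1.4-fold lower number from compound 2 to compound 3 (0.14 log units; within the scatter)), so the earlier gain is not tied to thiophen-3-yl alone. Nothing available here explains why these groups behave this way.

Going by these compounds, whether the ring itself matters remains open, since an open-chain dimethylamino group could be compared with piperidin-1-yl. A morpholin-4-yl ring would test whether a ring oxygen is accepted at this position.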